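Swapping an Acid Chain for an Ester Piperidine

The source may report more compounds than this note shows. Statements on the series, on what has been measured and on what is new or still open speak of the compounds shown alone.

Measured compounds:
compound 1, `CC(C)(C)OC(=O)NCCCCCNC(=O)CN1CN(c2ccccc2)C2(CCN(C(=O)c3ccc(C(C)(C)C)cc3)CC2)C1=O`: 13700 nM
compound 2, `CC(C)(C)c1ccc(C(=O)N2CCC3(CC2)C(=O)N(CC(=O)NCCC(=O)O)CN3c2ccccc2)cc1`: 11400 nM
compound 3, `CCc1nn(CC)c(C2CCN(C(=O)CN3CN(c4ccccc4)C4(CCN(C(=O)c5ccc(C(C)(C)C)cc5)CC4)C3=O)CC2)c1CC`: 4600 nM

In an assay on HEK293 cells for displacement of a labelled ligand from NPC1-like intracellular cholesterol transporter 1 (Homo sapiens) (a higher number here means a weaker inhibitor, a lower number a stronger inhibitor), compound 2 stands second highest of the three numbers with 11400 nM. Its nearest neighbour is compound 1, the step of a 1.2-fold lower number from compound 1 to compound 2 (0.08 log units; within the scatter) lying within the scatter; its furthest is compound 3, whose 4600 nM sits lower, beyond the scatter.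

Compound 4, `CCOC(=O)C1CCCN(C(=O)CN2CN(c3ccccc3)C3(CCN(C(=O)c4ccc(C(C)(C)C)cc4)CC3)C2=O)C1`, differs from compound 2 in one place: 3-(ethoxycarbonyl)piperidin-1-yl in place of (2-carboxyethyl)amino on a carbonyl carbon

Within the data shown here, only one measured step is available, and it exchanged one chain end for another on the same side of the molecule without moving the number beyond the scatter. It therefore gives little guidance for a change that removes both hydrogen-bond donors and brings in a six-membered ring. Among the measured compounds shown here, compound 3, which also carries a ring-bearing amide on that carbonyl carbon, gives a lower number than compound 2, but no step between those two has been worked out, and a single pair is a thin basis.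

For compound 4 a modestly lower number is expected, 6500 nM, with a range from 2500 nM to 16000 nM. This estimate corresponds to the step of a 1.8-fold lower number from compound 2 to compound 4 (0.24 log units; within the scatter) and is expected to lie near the edge of the scatter.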

Compound 4, half-maximal inhibitory concentration: 8200 nM
The estimate for compound 4 lay 1.3-fold (0.10 log units) below the measured number; the measured number falls inside the stated range.
By their numbers in this assay, from the lowest: compounds 3, 4, 2 and 1 (each within the scatter of the next, the first and the last beyond it).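

In this assay, replacing (2-carboxyethyl)amino with 3-(ethoxycarbonyl)piperidin-1-yl on a carbonyl carbon gave a 1.4-fold lower number from compound 2 to compound 4 (0.14 log units; within the scatter). The earlier step had changed only the far end of the chain, whereas this one replaces the group attached to the carbonyl carbon, going from a chain with no ring and 2 hydrogen-bond donors to a larger group with a six-membered non-aromatic ring and 0 hydrogen-bond donors, and the number still stays within the scatter. No measurement shown bears on why this exchange leaves the number so little changed.

Because the ring and the ester entered in a single step, the compounds shown do not separate their contributions: a piperidin-1-yl group carrying a carboxylic acid in place of the ethoxycarbonyl, or an unsubstituted piperidin-1-yl group, would be needed to tell them apart. Also open, on these data alone, is how an open chain ending in an ethyl ester would read at this carbonyl carbon, since it would keep the amide hydrogen of compound 2 while replacing only its carboxylic acid.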